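From Tert-Butyl to Chloro on the Shared Core

The source may report more compounds than this note shows. Statements on the series, on what has been measured and on what is new or still open speak of the compounds shown alone.

Compound 3 (`CC(C)(C)c1ccc(NS(=O)(=O)c2ccc(N3CCNC3=O)cc2)cc1`) gives > 1000 nM in a functional assay on MCF7 cells (Homo sapiens) for antiproliferative activity, read by sulforhodamine B assay, with a stated time of 48 h (on this read-out lower numbers stand for stronger inhibition and higher numbers for weaker inhibition), as a limit of the assay and not a number. Compound 2 (`CCCCCCCc1ccc(NS(=O)(=O)c2ccc(N3CCNC3=O)cc2)cc1`) gives > 1000 nM in this assay as a limit too. These two compounds make up the limit of > 1000 nM in this assay, at which 2 of the 3 values shown sit, in the set. Compound 1 (`O=C1NCCN1c1ccc(S(=O)(=O)Nc2ccc(I)cc2)cc1`) alone gives a number, 600 nM in this assay with iodo on that carbon.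

Compound 4 (`O=C1NCCN1c1ccc(S(=O)(=O)Nc2ccc(Cl)cc2)cc1`) carries chloro in place of tert-butyl on an aromatic carbon. Among the compounds with values here, two measured steps bear on this change (an at least 1.6-fold higher number from compound 1 to compound 2 (0.22 log units; that floor lies within the scatter) and an at least 1.6-fold higher number from compound 1 to compound 3 (0.22 log units; that floor lies within the scatter)), and both are floors only. The step between the two limits stays unreadable (a step that the two limits leave unreadable from compound 2 to compound 3).

The expectation rests on compound 1 (600 nM), whose iodo, unlike heptyl and tert-butyl, leaves a measured number. A modest move toward a lower number is therefore expected (an at least 1.3-fold lower number from compound 3 to compound 4 (0.12 log units; that floor lies within the scatter)), though compound 4 may also end at the limit. The estimated value for compound 4 is 750 nM with an expected range (300 nM to 1800 nM).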

Compound 4, half-maximal inhibitory concentration: 170 nM
Compound 4: middle estimate off by 4.4-fold (0.64 log units), on the high side; measured number outside the range, below it.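

In this assay this aromatic carbon proves sensitive to the group it carries, and the exchange of iodo for chloro gives a step beyond the scatter (a 3.5-fold lower number from compound 1 to compound 4 (0.55 log units; beyond the scatter)). The earlier compounds shown here offered only floors within the scatter, whereas chloro in place of the larger groups now clears it, both for tert-butyl (an at least 5.8-fold lower number from compound 3 to compound 4 (0.76 log units; beyond the scatter)) and for heptyl (an at least 5.8-fold lower number from compound 2 to compound 4 (0.76 log units; beyond the scatter)). These last two steps are still floors, and the step between compound 2 and compound 3 cannot be read, as both compounds stand at a limit and not a number: the limit of > 1000 nM in this assay, at which 2 of the 4 values shown sit.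

On these data alone, whether the number tracks the single heavy atom of chloro or something else about that group stays open. Fluoro, methoxy, an amine or a carboxylic acid on this carbon would bear on that question.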